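Cytotoxicity on Vero cells: amide to carbonyl-linked butylamino

The source may hold more compounds than are shown below. What is called first, only, known or untested is meant among the compounds shown, and "the series" means these compounds.

Compound 1 `CCCc1ccc(C(=O)Nc2cc3nc(C4CCCCC4)[nH]c3cc2N(C)C)cc1` was tested in an ADME assay on Vero cells (Chlorocebus sabaeus) for cytotoxicity, read by resazurin assay, with a stated time of 3 days; a lower number here means a stronger inhibitor, a higher number a weaker inhibitor. In this assay compound 1 gives > 100 ug/mL, which is a limit of the assay and not a number. Compound 2 `CCOCCOC(=O)Nc1cc2nc(C3CCCCC3)[nH]c2cc1N1CCCC1` in this assay also gives > 100 ug/mL, again a limit rather than a measured number. For compound 3 `CCCc1ccc(C(=O)Nc2cc3nc(C4CCCCC4)[nH]c3cc2N(CC)CC)cc1` this assay records "not determined" (no result reported). Among the measured compounds shown here, compound 1 therefore stands at the limit shared with compound 2 (the limit of > 100 ug/mL in this assay, at which 2 of the 3 values shown sit), and no step between measured compounds can be sized.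

Compound 4 `CCCCNC(=O)Nc1cc2nc(C3CCCCC3)[nH]c2cc1N(C)C` differs from compound 1 in one place (butylamino in place of 4-propylphenyl on a carbonyl carbon). With both measured values of the series sitting at the limit, no direction beyond the scatter is expected for the step from compound 1 to compound 4 in this assay, and the change from compound 1 to compound 4 is estimated as a number no higher from compound 1 to compound 4 (the limit leaves the size open). For compound 4 in this assay the estimated value is 100 ug/mL, with a range from 50 ug/mL to 200 ug/mL, most likely reported again only as a limit.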

Compound 4, half-maximal inhibitory concentration: > 100 ug/mL
Compound 4: no number, only a limit (the forecaster's own chance of this, stated with the estimate: 70%); the middle value lies on the limit itself.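

No step can be read between compound 1 and compound 4, because both sit at the same limit, which is not a number: the limit of > 100 ug/mL in this assay, at which 3 of the 4 values shown sit.

The compounds shown leave open whether butylamino in place of 4-propylphenyl on a carbonyl carbon changes the read-out at all.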